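The compounds below may be only part of what the source reports. "The series", "measured", "known", "first", "only" and "open" are said of these compounds alone.

Compound 1 `O=C(Nc1ccc([N+](=O)[O-])cc1Cl)c1cc(-c2ccc(F)cc2F)ccc1O`: < 1 ug/mL
Compound 2 `O=C(Nc1ccc(C(F)(F)F)cc1Cl)c1cc(Cl)ccc1O`: < 1 ug/mL
Compound 3 `O=C(Nc1ccc(C(F)(F)F)cc1Cl)c1cc(Br)ccc1O`: < 1 ug/mL

In a physicochemical assay for solubility (a lower number here means a less soluble compound, a higher number a more soluble compound), compound 3 gives < 1 ug/mL, which is a limit and not a number. The whole set stands at the limit of < 1 ug/mL in this assay, at which 3 of the 3 values shown sit.

Compound 4 `O=C(Nc1ccc(C(F)(F)F)cc1Cl)c1cc(-c2ccc(F)cc2F)ccc1O` has 2,4-difluorophenyl in place of bromo on an aromatic carbon. Among the compounds with values here, the one measured step, a step that the two limits leave unreadable from compound 2 to compound 3, exchanges chloro for bromo and gives no readable size. Compound 1 already carries the 2,4-difluorophenyl and gives < 1 ug/mL, also a limit. On this evidence, no change beyond the scatter is expected in this assay, and the estimated step is a step that the limit leaves unreadable from compound 3 to compound 4. For compound 4 the estimated value is 0.5 ug/mL, with an expected range from 0.2 ug/mL to 1.2 ug/mL.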

Compound 4, solubility: < 1 ug/mL
Compound 4 ended at the assay's limit; the forecaster's own chance of this, stated with the estimate: 90%; the middle value does not contradict the limit.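

In this assay compound 4 stands as a limit, as do compound 1, compound 2 and compound 3, and no step among these compounds can be read. The compounds shown leave open how soluble each one actually is, and whether any of these exchanges of groups changes it.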